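Swapping the amide aryl group on a lipophilic proline amide

The source may report more compounds than this note shows. Statements on the series, on what has been measured and on what is new or still open speak of the compounds shown alone.

Compound 1 `COc1ccc(NC(=O)[C@H]2CCCN2C(=O)C2(c3cccc(Cl)c3)CCCC2)nc1` stands at the top of the three measured values in a physicochemical assay for lipophilicity, at pH 7.4 (on this read-out higher numbers stand for higher lipophilicity and lower numbers for lower lipophilicity), where it gives 6.8. Compound 3 `O=C(Nc1ccc2[nH]ncc2n1)[C@H]1CCCN1C(=O)C1(c2ccc(Cl)cc2)CCC1` comes nearest to it, giving 4.7 in this assay, a number that sits below compound 1 by a margin well beyond the usual scatter. Furthest from compound 1 lies compound 2 `O=C(Nc1ccc2[nH]ncc2n1)[C@H]1COCCN1C(=O)C1(c2ccc(Cl)cc2)CC(F)(F)C1`, which gives 4.5 in this assay, again a gap clearly beyond the scatter. Compounds 2 and 3 themselves differ by an amount that falls within the scatter of the method.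

Compound 4 `O=C(Nc1ccc(O)cc1)[C@H]1CCCN1C(=O)C1(c2cccc(Cl)c2)CCCC1` has not yet been measured. It differs from compound 1 in a single place: 4-hydroxyphenyl in place of 5-methoxypyridin-2-yl on an amide-type nitrogen. A hydrogen-bond donor enters with the 4-hydroxyphenyl group, while the ring nitrogen and the methoxy oxygen of the 5-methoxypyridin-2-yl group leave. For the measured compounds named here, no pair of measured compounds in this set shows this particular exchange, so the size of the step cannot be read off directly.

On the balance of what leaves and what enters, a step of a number 0.20 log units lower from compound 1 to compound 4 (within the scatter) is expected, small enough to stay within the usual scatter and leaning, if anywhere, slightly downward. Compound 4 is therefore estimated to give 6.6 in this assay, with a range from 5.9 to 7.3.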

Compound 4, distribution coefficient: 5.5
Estimate against measurement, compound 4: 1.10 log units above, and the stated range ends above it.
By their numbers in this assay, from the lowest: compounds 2 and 3 (each within the scatter of the next); then compound 4; then compound 1.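

For the compounds shown here, the exchange of 5-methoxypyridin-2-yl for 4-hydroxyphenyl on an amide-type nitrogen gives, in this assay, a number 1.30 log units lower from compound 1 to compound 4 (beyond the scatter), and this is the first step in the set that can be read across a single place. It shows that this position is not a silent one for this read-out: with the rest of compound 1 held fixed, a change confined to this aryl group is enough to produce a large step. The earlier gaps could not show this, since compound 2 and compound 3 differ from compound 1 in more than one place, and nothing available here accounts for the size of the new step.

The exchange alters several things at once, as the ring nitrogen and the methoxy oxygen leave while a hydroxyl enters, so the compounds shown do not divide the step among these features. Also open, as far as these compounds go, is how a plain phenyl, a phenyl carrying a methoxy group or a phenyl carrying an amine would fall on this read-out, and whether the same exchange gives a step of similar size on another core.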